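This account rests on a few compounds, and the source may have more. Where it says the series, first, only, none or still open, it means among the compounds named here.

Compound 3 `O=C(O)/C(S)=C/c1c[nH]c2c(Br)cccc12` gives 70 nM in an assay on isolated protein for inhibition of Calpain-1 catalytic subunit (Sus scrofa) (on this read-out lower numbers stand for stronger inhibition and higher numbers for weaker inhibition), the lowest of the three numbers shown. Compound 1 `O=C(O)/C(S)=C/c1c[nH]c2c(F)cccc12` gives 110 nM in this assay, and compound 2 `O=C(O)/C(S)=C/c1c[nH]c2c(I)cccc12` gives 220 nM. The change to compound 4 `O=C(O)/C(S)=C/c1c[nH]c2c(Cl)cccc12` is chloro in place of bromo on an aromatic carbon. The halogen swaps already measured bear on it: a 1.6-fold lower number from compound 1 to compound 3 (0.20 log units; within the scatter), a 3.1-fold lower number from compound 2 to compound 3 (0.50 log units; beyond the scatter) and a 2.0-fold higher number from compound 1 to compound 2 (0.30 log units; within the scatter). Chloro itself has not been measured, but the exchanges among fluoro, bromo and iodo moved this assay by a modest amount at most, so a small step is expected. Compound 4 is therefore expected to show a 1.1-fold higher number from compound 3 to compound 4 (0.06 log units; within the scatter), nothing beyond the scatter. The estimate for compound 4 is 80 nM, with a range from 40 nM to 160 nM.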

Compound 4, half-maximal inhibitory concentration: 90 nM
For compound 4 the middle estimate is 1.1-fold (0.05 log units) below the measured one; low and high end bracket the measured number.
By their numbers in this assay, from the lowest: compounds 3, 4, 1 and 2 (each within the scatter of the next, the first and the last beyond it).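

In this assay, chloro at this position adds a fourth halogen, and the step to it from bromo (a 1.3-fold higher number from compound 3 to compound 4 (0.11 log units; within the scatter)) and from fluoro (a 1.2-fold lower number from compound 1 to compound 4 (0.09 log units; within the scatter)) stays within the scatter. Iodo is separated from chloro (a 2.4-fold lower number from compound 2 to compound 4 (0.39 log units; beyond the scatter)) as it is from bromo, but not from fluoro, so compound 1 goes against any clean split between iodo and the other halogens. The data offer no explanation for these numbers. Whether an amine or a methoxy group at this position would stay in this range remains open, since only halogens are shown there.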